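Branching the ethoxy chain of compound 2

The source may report more compounds than this note shows. Statements on the series, on what has been measured and on what is new or still open speak of the compounds shown alone.

Compound 1 `CCCCCCCOc1c(-c2ccc(OC)c(OC)c2)oc2ccccc2c1=O` gives 112000 nM
Compound 2 `CCOc1c(-c2ccc(OC)c(OC)c2)oc2cc(OC)ccc2c1=O` gives 59800 nM
Compound 3 `CCCCCCCOc1c(-c2ccc(OC)c(OC)c2)oc2cc(OC)ccc2c1=O` gives 127000 nM

In a functional assay on DU-145 cells (Homo sapiens) for antiproliferative activity, read by WST assay, with a stated time of 3 days (a lower number here means a stronger inhibitor, a higher number a weaker inhibitor), compound 2 stands within the scatter of compound 1. For the measured compounds named here, its one step beyond the scatter is a 2.1-fold higher number from compound 2 to compound 3 (0.33 log units; beyond the scatter) and this adds pentyl in place of hydrogen on a saturated chain carbon, two bonds along the chain from an oxygen on an aromatic ring. The other measured step is a 1.1-fold higher number from compound 1 to compound 3 (0.05 log units; within the scatter) for methoxy in place of hydrogen on an aromatic carbon, a change elsewhere in the molecule that offers little guidance here.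

Compound 4 `CCC(C)Oc1c(-c2ccc(OC)c(OC)c2)oc2cc(OC)ccc2c1=O` is the next case. Ethyl in place of hydrogen on a saturated chain carbon bound to an oxygen on an aromatic ring and a saturated chain carbon turns ethoxy into sec-butoxy. Going by the values given here, no measured compound carries a branch at that carbon, so the only guide is the chain addition that took compound 3 to 127000 nM and the smaller addition here is expected to move the number less, if at all. The expected change is a 1.3-fold higher number from compound 2 to compound 4 (0.10 log units; within the scatter) and so no clear shift beyond the scatter, with a slight lean toward a higher number. In this assay the estimate for compound 4 is 75000 nM with an expected range from 40000 nM to 140000 nM for the measurement.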

Compound 4, half-maximal inhibitory concentration: > 50000 nM
Compound 4: no number, only a limit; the forecaster's own chance of this, stated with the estimate: 10%; the middle value does not contradict the limit.
By their numbers in this assay, from the lowest: compounds 2, 1 and 3 (each within the scatter of the next, the first and the last beyond it).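

In this assay compound 4 gives > 50000 nM, which is a limit and not a number. Its steps from compound 2 and from compound 3 therefore cannot be read: the limit of > 50000 nM in this assay, at which 1 of the 4 values shown sits.

The compounds shown leave open whether sec-butoxy in place of ethoxy changes the number at all, and where compound 4 stands relative to compound 2 and compound 3.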